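Triazole attachment swap in the benzamide series

The compounds below may be only part of what the source reports. "The series", "measured", "known", "first", "only" and "open" are said of these compounds alone.

Measured so far:
compound 1 `O=C(NCCCCCCCn1cc(-c2cccnc2)nn1)c1ccccc1-n1ccnn1` — 3.4 nM
compound 2 `O=C(NCCCCCCCn1cc(-c2cccnc2)nn1)c1ccccc1-c1c[nH]nn1` — 42.5 nM

In an assay for inhibition of Nicotinamide phosphoribosyltransferase (Mus musculus), read by fluorescence, with a stated time of 1 h, in the presence of a further agent that is not named here (a higher number here means a weaker inhibitor, a lower number a stronger inhibitor), compound 2 gives 42.5 nM, the highest of the two numbers; compound 1 gives 3.4 nM. Within the data shown here, the only measured step, a 13-fold higher number from compound 1 to compound 2 (1.10 log units; beyond the scatter), separates them. Compound 3 `CN(C)Cc1cn(-c2ccccc2C(=O)NCCCCCCCn2cc(-c3cccnc3)nn2)nn1` carries 4-((dimethylamino)methyl)-1H-1,2,3-triazol-1-yl in place of 1H-1,2,3-triazol-4-yl on an aromatic carbon. Among the measured compounds shown here, the entering group shares the 1H-1,2,3-triazol-1-yl pattern of compound 1, so that step is expected to run back in the opposite direction, while the (dimethylamino)methyl part has no measured precedent. Compound 3 is therefore expected to give 5 nM, with a range from 1.5 nM to 20 nM, which is estimated to mean an 8.5-fold lower number from compound 2 to compound 3 (0.93 log units; beyond the scatter).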

Compound 3, half-maximal inhibitory concentration: 42.4 nM
Estimate against measurement, compound 3: 8.5-fold (0.93 log units) below; measured number outside the range, above it.
By their numbers in this assay, from the lowest: compound 1; then compounds 3 and 2 (each within the scatter of the next).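

In this assay, (dimethylamino)methyl in place of hydrogen on an aromatic carbon of the triazole gives a 12-fold higher number from compound 1 to compound 3 (1.10 log units; beyond the scatter) and so is not tolerated without cost at this place. The 1H-1,2,3-triazol-1-yl attachment alone therefore does not secure the low number of compound 1, as a 1.0-fold lower number from compound 2 to compound 3 (0.00 log units; within the scatter) leaves the substituted triazole level with the 1H-1,2,3-triazol-4-yl analogue. No available evidence bears on the reason for this result.

Still open, on these data alone, is whether the step follows the tertiary amine or the added size of the substituent. A methyl, hydroxymethyl or carboxylic acid in place of that hydrogen would help separate the two.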